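Swapping Methyl for Chloro on the Sulfonyl Ring

The source may report more compounds than this note shows. Statements on the series, on what has been measured and on what is new or still open speak of the compounds shown alone.

Compound 1 `CCN(C(=O)CN(c1cc(N(C)C)ccc1Cl)S(=O)(=O)c1ccc(OC)c(OC)c1)c1cccc(C)n1` gives 17 nM in a functional assay on CHO cells for inhibition of Orexin/Hypocretin receptor type 1 (Homo sapiens), read by FLIPR and calcium flux; on this read-out higher numbers stand for weaker inhibition and lower numbers for stronger inhibition.
Compound 2 `CCN(CC)C(=O)CN(c1ccc(C)cc1)S(=O)(=O)c1cccc(C)c1` gives only a limit of the assay in this assay, > 10000 nM.
Compound 3 `CCN(CC)C(=O)CN(c1cc(Cl)ccc1N(C)C)S(=O)(=O)c1ccc(OC)c(OC)c1` gives 4880 nM in this assay.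

These three compounds share the same sulfonamide-acetamide core, and all were tested in this assay on cells. Compound 1 is the only one of the three that reaches a low number. Compound 3 sits at a far higher number than compound 1. For compound 2 the assay reports no number at all, only a limit, so compound 2 sits at the limit of > 10000 nM in this assay, at which 1 of the 3 values shown sits; its structure stands beside it above, and it differs from compounds 1 and 3 in both aromatic rings.

Compound 4 `CCN(CC)C(=O)CN(c1ccc(C)cc1)S(=O)(=O)c1cccc(Cl)c1` is the compound still to be measured. It differs from compound 2 in a single place: chloro in place of methyl on an aromatic carbon. Cut one bond further out, the same change reads 3-methylphenyl to 3-chlorophenyl. Among the measured compounds shown here, no measured pair among the three compounds shows this same change, so nothing here tells how large its effect is. Since compound 2 already sits at the limit of the assay, the step from compound 2 to compound 4 is expected to be none beyond the usual scatter, a number no higher from compound 2 to compound 4 (the limit leaves the size open). Compound 4 is estimated at 10000 nM, with a range from 3000 nM to 30000 nM, and most likely the assay will again report only a limit.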

Compound 4, half-maximal inhibitory concentration: > 10000 nM
Compound 4: only a limit was reported; the forecaster's own chance of this, stated with the estimate: 75%; the middle value sits exactly at the limit.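

Compound 2 and compound 4 each give only a limit of the assay, not a number, so no step can be read between them: the limit of > 10000 nM in this assay, at which 2 of the 4 values shown sit.

The compounds shown leave open whether placing chloro instead of methyl on this aromatic carbon changes inhibition at all, and if so, by how much.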